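This account rests on a few compounds, and the source may have more. Where it says the series, first, only, none or still open, it means among the compounds named here.

In a functional assay on HCT-116 cells (Homo sapiens) for antiproliferative activity, read by MTT assay, with a stated time of 24 h (a higher number here means a weaker inhibitor, a lower number a stronger inhibitor), compound 1 (`COc1cc(OC)c(-c2coc3cc(OCc4ccccc4)ccc3c2=O)cc1OC`) gives 2280 nM, compound 2 (`COc1cc(OC)c(-c2coc3cc(OCc4ccccc4F)ccc3c2=O)cc1OC`) gives 2900 nM and compound 3 (`COc1cc(OC)c(-c2coc3cc(OCc4ccccc4C)ccc3c2=O)cc1OC`) gives 2900 nM. Compound 3 is therefore level with compound 2 and within the scatter of compound 1. Compound 4 (`COc1cc(OC)c(-c2coc3cc(OCc4ccc(Cl)cc4)ccc3c2=O)cc1OC`) differs from compound 3 as follows: 4-chlorophenyl in place of 2-methylphenyl on a saturated chain carbon bound to an oxygen on an aromatic ring. Among the compounds with values here, three measured steps bear on this change: a 1.3-fold higher number from compound 1 to compound 2 (0.10 log units; within the scatter), a 1.3-fold higher number from compound 1 to compound 3 (0.10 log units; within the scatter) and no change at the digits printed from compound 2 to compound 3 (within the scatter). None of them involves a 4-chlorophenyl group, so direct evidence is lacking and the range stays wide. No step beyond the scatter is expected in this assay, and the expected step is a 1.2-fold lower number from compound 3 to compound 4 (0.06 log units; within the scatter). The estimate for compound 4 is 2500 nM, with an expected range of 1000 nM to 5500 nM.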

Compound 4, half-maximal inhibitory concentration: 4450 nM
For compound 4 the middle estimate is 1.8-fold (0.25 log units) below the measured one, within the range that was stated.
By their numbers in this assay, from the lowest: compounds 1, 2, 3 and 4 (each within the scatter of the next).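

In this assay, 4-chlorophenyl in place of 2-methylphenyl gives a 1.5-fold higher number from compound 3 to compound 4 (0.19 log units; within the scatter), and in place of 2-fluorophenyl it gives a 1.5-fold higher number from compound 2 to compound 4 (0.19 log units; within the scatter). Set against the benzyl group without a substituent, the 4-chlorobenzyl group gives a 2.0-fold higher number from compound 1 to compound 4 (0.29 log units; within the scatter), so all four benzyl groups shown remain within the scatter at this position. No available evidence accounts for these numbers.

Still open, going by these compounds, is whether an amine or a carboxylic acid on this ring, or a longer chain in place of the benzyl group, would give a step beyond the scatter.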